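A few compounds are considered here, and "the series" means these few. Any claim that something is new, unique, unknown or untested is made for them only; others in the source may bear on it.

Working notes on the series, step from compound 1 to compound 3.

Compound 1 `C#CCn1cc(C(=O)NC(CC(=O)Nc2ccccc2)c2ccccc2)c(=O)c2cc(F)c(Cl)nc21` is the reference point. In a functional assay on A549 cells (Homo sapiens) for cytotoxicity, read by MTT assay, with a stated time of 72 h (on this read-out lower numbers stand for stronger inhibition and higher numbers for weaker inhibition), compound 1 gives > 10000 nM, which is a limit of the assay and not a number. Within the data shown here, its single measured neighbour is compound 2 `C#CCn1cc(C(=O)NC(CC(=O)Nc2ccccn2)c2ccccc2)c(=O)c2cc(F)c(Cl)nc21`, in which pyridin-2-yl replaces phenyl on an amide-type nitrogen. In this assay compound 2 gives > 10000 nM, again a limit rather than a number. The step that the two limits leave unreadable from compound 1 to compound 2 therefore cannot be read for size or direction; what is known is only (the limit of > 10000 nM in this assay, at which 2 of the 2 values shown sit).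

Compound 3 `C#CCn1cc(C(=O)NC(CC(=O)NC2CCCC2)c2ccccc2)c(=O)c2cc(F)c(Cl)nc21` is the next member to be measured. Its difference from compound 1 is cyclopentyl in place of phenyl on an amide-type nitrogen. Among the measured compounds shown here, no measured step bears on this change in readable form: the only step available, from compound 1 to compound 2, is itself hidden by the limit. With both measured compounds sitting at the limit, the expectation for compound 3 is that it also returns only a limit in this assay, so the step that the limit leaves unreadable from compound 1 to compound 3 is expected to be unreadable rather than a real gain. The estimated half-maximal inhibitory concentration for compound 3 is 15000 nM, with a range from 4000 nM to 60000 nM.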

Compound 3, half-maximal inhibitory concentration: 6100 nM
Beside the measured number, compound 3's estimate is 2.5-fold (0.39 log units) above it, and the stated range covers the measured number.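

Among these compounds, compound 3 is the first member of the series to give a number rather than a limit in this assay, so a change of group on this amide-type nitrogen can bring the read-out into the measurable range. The change gives an at least 1.6-fold lower number from compound 1 to compound 3 (0.21 log units; that floor lies within the scatter), and it gives an at least 1.6-fold lower number from compound 2 to compound 3 (0.21 log units; that floor lies within the scatter); both are floors, so the true steps may be larger, but these floors alone do not establish a gain beyond the scatter. Among the three compounds shown, cyclopentyl, the one non-aromatic ring, is the only group with a readable value, while the compounds carrying phenyl and pyridin-2-yl stay at a limit of the assay: the limit of > 10000 nM in this assay, at which 2 of the 3 values shown sit.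

Open is whether ring size or the loss of the aromatic ring matters, since cyclopentyl is the only non-aromatic group shown at this place. Going by these compounds, a cyclohexyl ring, a straight butyl chain or a ring bearing an amine on the same nitrogen would help separate these readings, and how much stronger the read-out can become through this position remains unknown.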